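Second chloro on the aryl ring of compound 2

The source may hold more compounds than are shown below. What is called first, only, known or untested is meant among the compounds shown, and "the series" means these compounds.

Compound 1 `C=CCn1c(=O)/c(=C\c2ccccc2C(F)(F)F)[nH]c(=O)/c1=C\c1ccccc1OC` and compound 2 `C=CCn1c(=O)/c(=C\c2ccccc2Cl)[nH]c(=O)/c1=C\c1ccccc1OC` share one core and differ on a single aromatic carbon; in a functional assay on HL-60 cells (Homo sapiens) for cytotoxicity, read by CCK-8 assay, with a stated time of 72 h (on this read-out higher numbers stand for weaker inhibition and lower numbers for stronger inhibition), compound 1 gives 4600 nM and compound 2 gives 4200 nM. For the measured compounds named here, the only step known, a 1.1-fold lower number from compound 1 to compound 2 (0.04 log units; within the scatter), resolves nothing, so compound 2 stands lowest of the two numbers yet within the scatter of compound 1. Compound 3 `C=CCn1c(=O)/c(=C\c2cccc(Cl)c2Cl)[nH]c(=O)/c1=C\c1ccccc1OC` carries a further change: chloro in place of hydrogen on an aromatic carbon. Going by the values given here, no measured step adds a chloro to this ring; the change is expected to stay within the scatter, a 1.1-fold lower number from compound 2 to compound 3 (0.02 log units; within the scatter). Compound 3 is therefore estimated at 4000 nM, range 1800 nM to 9000 nM.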

Compound 3, half-maximal inhibitory concentration: 2000 nM
Estimate against measurement, compound 3: 2.0-fold (0.30 log units) above, within the range that was stated.
By their numbers in this assay, from the lowest: compound 3; then compounds 2 and 1 (each within the scatter of the next).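

In this assay, for the compounds shown here, adding a chloro ortho to a chloro group gives a 2.1-fold lower number from compound 2 to compound 3 (0.32 log units; beyond the scatter), the first change on this aryl ring to lie beyond the scatter. The 2,3-dichlorophenyl group also separates from 2-(trifluoromethyl)phenyl, with a 2.3-fold lower number from compound 1 to compound 3 (0.36 log units; beyond the scatter), although both steps are modest. No evidence is available to explain the gain from this second chloro.

Still open, from the compounds shown here alone, is whether the gain is specific to chloro at this position, or whether a nitrile or an amine there would give a similar number.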